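Piperazine nitrogen substituent: aryl to pyrimidinyl on the amide series

A few compounds are considered here, and "the series" means these few. Any claim that something is new, unique, unknown or untested is made for them only; others in the source may bear on it.

Two members of the series have been run in an assay on membranes from brain for displacement of a labelled ligand from Sigma non-opioid intracellular receptor 1 (Cavia porcellus), read by scintillation counting, with a stated time of 120 min; on this read-out higher numbers stand for weaker inhibition and lower numbers for stronger inhibition. Compound 1 `Cc1cccc2sc(NC(=O)CCN3CCN(C(C)C)CC3)nc12` gives 1300 nM. Compound 2 `Cc1ccccc1N1CCN(CCC(=O)Nc2nc3c(C)cccc3s2)CC1` gives 1000 nM. Going by the values given here, the only step between measured compounds, a 1.3-fold lower number from compound 1 to compound 2 (0.11 log units; within the scatter), is the exchange of isopropyl for 2-methylphenyl on the amine nitrogen in the ring, and it falls inside the usual scatter, so compound 2 stands together with compound 1 rather than apart from it.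

Compound 3 `Cc1cccc2sc(NC(=O)CCN3CCN(c4ncccn4)CC3)nc12` carries the change (pyrimidin-2-yl in place of 2-methylphenyl on an amine nitrogen in a ring), pyrimidin-2-yl in place of 2-methylphenyl on an amine nitrogen in a ring. Among the compounds with values here, no measured step in this assay covers an exchange of one six-membered aromatic ring for another at this position; the single step available, a 1.3-fold lower number from compound 1 to compound 2 (0.11 log units; within the scatter), shows that the ring nitrogen has so far tolerated a change from a branched alkyl to an aromatic group without a shift beyond the scatter. On that basis the expected step of a 1.5-fold higher number from compound 2 to compound 3 (0.18 log units; within the scatter) is none beyond the scatter, in no firm direction. Compound 3 is therefore estimated at 1500 nM in this assay, with a range of 500 nM to 5000 nM.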

Compound 3, inhibition constant: 505 nM
Beside the measured number, compound 3's estimate is 3.0-fold (0.47 log units) above it; measured number inside the range.
By their numbers in this assay, from the lowest: compounds 3, 2 and 1 (each within the scatter of the next, the first and the last beyond it).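

In this assay, going by these compounds alone, pyrimidin-2-yl in place of 2-methylphenyl is the first exchange of one six-membered aromatic ring for another on this amine nitrogen, and it gives a 2.0-fold lower number from compound 2 to compound 3 (0.30 log units; within the scatter). Compound 3 therefore stands with compound 2, and a ring with 2 hetero atoms and 2 hydrogen-bond acceptors is accepted at this position as well as a ring of carbon only. Against isopropyl, the same group gives a 2.6-fold lower number from compound 1 to compound 3 (0.41 log units; beyond the scatter), the first step at this position to pass the scatter, though only a modest one, so the position is not wholly indifferent to its substituent. No measurement available here bears on the reason for these steps.

The exchange from 2-methylphenyl to pyrimidin-2-yl alters the ring atoms and removes the methyl group together, so unsubstituted phenyl and pyridin-2-yl on the same amine nitrogen are the groups that would separate the two changes. As far as these compounds go, it also remains open whether pyrimidin-2-yl keeps its step over isopropyl with a longer chain linking the amide to this ring.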